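Shortening the carbamate ester in a pyrazole amide series

The source may hold more compounds than are shown below. What is called first, only, known or untested is meant among the compounds shown, and "the series" means these compounds.

Within the data shown here, compound 2 `CCN1CCN(c2cc(Nc3cc(C)nn3C(=O)OC(C)(C)C)nc(N[C@H]3CCN(C(=O)c4ccc(Cl)cc4F)C3)n2)CC1`, carrying tert-butoxy on a carbonyl carbon, gives the lowest of the two numbers so far in an ADME assay on the whole organism (Mus musculus, strain ICR) for pharmacokinetics, read by LC-MS, with a stated time of 24 h, at a dose of 2 mg/kg by the intravenous route (on this read-out higher numbers stand for fast clearance and lower numbers for slow clearance), namely 38 mL/min/kg. Its nearest neighbour is compound 1 `CCN1CCN(c2cc(Nc3cc(C)nn3C(=O)C(C)(C)C)nc(N[C@H]3CCN(C(=O)c4ccc(Cl)cc4F)C3)n2)CC1`, which differs only by tert-butyl in place of tert-butoxy on a carbonyl carbon; in this assay compound 1 gives 73.3 mL/min/kg, and the step of a 1.9-fold lower number from compound 1 to compound 2 (0.29 log units; within the scatter) lies within the scatter.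

Compound 3 `CCOC(=O)n1nc(C)cc1Nc1cc(N2CCN(CC)CC2)nc(N[C@H]2CCN(C(=O)c3ccc(Cl)cc3F)C2)n1` differs from compound 2 by ethyl in place of tert-butyl on an oxygen next to a carbonyl group. Among the measured compounds shown here, the only measured step, a 1.9-fold lower number from compound 1 to compound 2 (0.29 log units; within the scatter), concerns the atom attached to the carbonyl rather than the size of the alkyl group on the oxygen, so it bears only loosely on the present change, and no step in the data addresses exchanging tert-butyl for ethyl on that oxygen.

On this basis a step in this assay beyond the scatter is not expected, and the estimated change a 1.1-fold higher number from compound 2 to compound 3 (0.04 log units; within the scatter) is small. Compound 3 is therefore expected to give about 42 mL/min/kg, within a range of 20 mL/min/kg to 85 mL/min/kg.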

Compound 3, clearance: 20 mL/min/kg
Compound 3: the middle estimate sits 2.1-fold (0.32 log units) above what was measured; low and high end bracket the measured number.
By their numbers in this assay, from the lowest: compounds 3, 2 and 1 (each within the scatter of the next, the first and the last beyond it).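

Exchanging tert-butyl for ethyl on an oxygen next to a carbonyl group gives, in this assay, a 1.9-fold lower number from compound 2 to compound 3 (0.28 log units; within the scatter) and so, taken alone, this change stays within the scatter, as did the exchange of tert-butyl for tert-butoxy on the carbonyl carbon. Among these compounds, what the earlier compounds could not show is that the group on this carbonyl carbon can carry the read-out past the scatter: ethoxy in place of tert-butyl gives a 3.7-fold lower number from compound 1 to compound 3 (0.56 log units; beyond the scatter) and this is the first step to lie beyond it, though only modestly. Nothing measured here speaks to why the numbers fall as they do.

With only tert-butyl and ethyl on this oxygen, the compounds shown leave open whether the read-out follows the size of the group there, which methyl, isopropyl or a longer chain such as n-butyl would test. They also leave open how an amine on the carbonyl carbon, in place of the ethoxy, would read in this assay and whether the gain over compound 1 would hold.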